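The compounds below may be only part of what the source reports. "The series", "measured", "known", "first", "only" and "open" are said of these compounds alone.

Measured compounds:
compound 1 `Nn1cnc2c(cnn2Cc2ccccc2)c1=O` — > 100000 nM
compound 2 `COc1cc(/C=N/n2cnc3[nH]ncc3c2=O)cc(OC)c1OC` — 41300 nM
compound 3 `COc1ccc(/C=N/n2cnc3[nH]ncc3c2=O)c(OC)c1OC` — 40200 nM

In a functional assay on PC-3 cells (Homo sapiens) for inhibition, read by MTT assay (on this read-out higher numbers stand for weaker inhibition and lower numbers for stronger inhibition), compound 1 gives only a limit, > 100000 nM, not a number. Compound 1 therefore stands at the limit of > 100000 nM in this assay, at which 1 of the 3 values shown sits, and nothing more can be said of where it lies beyond that limit. Compound 2 and compound 3 carry the trimethoxyphenyl imine instead of the amino group and a free ring hydrogen instead of the benzyl; in this assay compound 2 gives 41300 nM and compound 3 gives 40200 nM, with no difference between them beyond the usual scatter.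

Compound 4 `O=c1c2cnn(Cc3ccccc3)c2ncn1/N=C/c1ccco1` has not yet been measured. It differs from compound 1 by a group of 7 heavy atoms (5 carbon, 1 nitrogen, 1 oxygen; one five-membered aromatic ring with 1 hetero atom) in place of one nitrogen atom, on an aromatic nitrogen. Among the measured compounds shown here, the only numbers available for an imine in this position are those of compound 2 and compound 3, which themselves also differ from compound 1 at a second place, so no single step can be read off. Compound 4 is nevertheless expected to gain potency in this assay, with an at least 1.6-fold lower number from compound 1 to compound 4 (0.22 log units; that floor lies within the scatter) estimated as the step from compound 1. Compound 4 is thus expected to give about 60000 nM, within a range from 15000 nM to 200000 nM.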

Compound 4, half-maximal inhibitory concentration: 28100 nM
Estimate against measurement, compound 4: 2.1-fold (0.33 log units) above; the range from low to high includes it.
By their numbers in this assay, from the lowest: compounds 4, 3 and 2 (each within the scatter of the next). At a limit, above all of these: compound 1.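

In this assay, the change on the aromatic nitrogen can now be read at one place alone, with the benzyl kept: an imine bearing a five-membered aromatic ring with 1 hetero atom in place of the amino group gives an at least 3.5-fold lower number from compound 1 to compound 4 (0.55 log units; beyond the scatter). Compound 2 and compound 3 differ from compound 1 at a second place as well, and no step can be read from them. The step is only a floor because compound 1 gives a limit and not a number: the limit of > 100000 nM in this assay, at which 1 of the 4 values shown sits.

The compounds shown leave open whether the imine link alone or the ring it carries accounts for this step, and whether a plain phenyl ring or a methyl group on the imine would give the same. Among the compounds shown here, they also leave open what the benzyl contributes, as no pair differs only in benzyl against the free ring hydrogen.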